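From trifluoromethoxy to tert-butyl on compound 3

The compounds below may be only part of what the source reports. "The series", "measured", "known", "first", "only" and "open" are said of these compounds alone.

Within the data shown here, in an ADME assay on HEK293 cells (Homo sapiens) for cytotoxicity, with a stated time of 72 h (a lower number here means that less compound is needed, a higher number that more compound is needed for the effect), compound 3 `Cc1cc(NC(=O)Nc2cccc(OC(F)(F)F)c2)c2ccccc2n1` gives 22000 nM as the only actual number so far. Compound 1 `Cc1cc(NC(=O)Nc2cccc(N(C)C)c2)c2ccccc2n1` reads > 25000 nM as a limit of the assay. Compound 2 `COc1cccc(NC(=O)Nc2cc(C)nc3ccccc23)c1` reads > 25000 nM as a limit too. The change to compound 4 `Cc1cc(NC(=O)Nc2cccc(C(C)(C)C)c2)c2ccccc2n1` tert-butyl in place of trifluoromethoxy on an aromatic carbon puts tert-butyl in place of trifluoromethoxy on an aromatic carbon. The measured steps at this same place are an at least 1.1-fold lower number from compound 1 to compound 3 (0.05 log units; that floor lies within the scatter) and an at least 1.1-fold lower number from compound 2 to compound 3 (0.05 log units; that floor lies within the scatter) and both give only a floor. Resting on these two steps, no change beyond the scatter is expected in this assay and the estimated size is a 1.1-fold lower number from compound 3 to compound 4 (0.04 log units; within the scatter) for this swap. Compound 4 is estimated at 20000 nM within a range of 9000 nM to 35000 nM and may also read as a limit.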

Compound 4, half-maximal effective concentration: > 25000 nM
Compound 4: no number, only a limit; the forecaster's own chance of this, stated with the estimate: 45%; middle value at least 1.2-fold (0.09 log units) from the limit.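

In this assay, tert-butyl in place of trifluoromethoxy gives an at least 1.1-fold higher number from compound 3 to compound 4 (0.05 log units; that floor lies within the scatter), so this swap gives only a floor and shows no change beyond the scatter. A group of carbon atoms alone at this position now joins dimethylamino and methoxy in reading as a limit, not a number, which leaves compound 3 alone with a measured value: the limit of > 25000 nM in this assay, at which 3 of the 4 values shown sit. The steps from compound 1 and compound 2 to compound 4 cannot be read, as both ends are limits.

As far as these compounds go, how far these limits lie from the true values stays open. So does whether a carboxylic acid or a longer chain at this position would give a readable number.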